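Cytotoxicity limits across the amine side chains

This account rests on a few compounds, and the source may have more. Where it says the series, first, only, none or still open, it means among the compounds named here.

- compound 1 `CNc1cc(Oc2c(OC)cc3cc(C#N)ccc3c2OC)nc(Nc2ccc(C#N)cc2)n1`: 239000 nM
- compound 2 `CCCNc1cc(Oc2c(OC)cc3cc(C#N)ccc3c2OC)nc(Nc2ccc(C#N)cc2)n1`: > 125000 nM (a limit)
- compound 3 `CCCC(C)Nc1cc(Oc2c(OC)cc3cc(C#N)ccc3c2OC)nc(Nc2ccc(C#N)cc2)n1`: > 125000 nM (a limit)

In an ADME assay on MT4 cells (Homo sapiens) for cytotoxicity, read by MTT assay, with a stated time of 5 days (a higher number here means that more compound is tolerated, a lower number that less compound is tolerated), compound 3 gives only a limit, and it stands at the limit of > 125000 nM in this assay, at which 2 of the 3 values shown sit. Compound 4 `COc1cc2cc(C#N)ccc2c(OC)c1Oc1cc(NCC2CC2)nc(Nc2ccc(C#N)cc2)n1` carries cyclopropylmethyl in place of 1-methylbutyl on a nitrogen on an aromatic ring. The closest measured change is a step that the two limits leave unreadable from compound 2 to compound 3. The others are a step that the limit leaves unreadable from compound 1 to compound 2 and a step that the limit leaves unreadable from compound 1 to compound 3. None of them gives a size. Among the compounds with values here, the only number is that of compound 1, at 239000 nM. No step beyond the scatter and no direction is expected, and the estimated step is a step that the limit leaves unreadable from compound 3 to compound 4. Compound 4 is estimated at 150000 nM, with an expected range of 70000 nM to 320000 nM.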

Compound 4, half-maximal cytotoxic concentration: > 125000 nM
Compound 4: no number, only a limit (the forecaster's own chance of this, stated with the estimate: 65%); the middle value lies beyond the limit too.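

Within the data shown here, compound 4 gives only a limit of > 125000 nM and so no step to it from compound 1, compound 2 or compound 3 can be read. The compounds shown leave open how compound 2, compound 3 and compound 4 rank.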